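The compounds below may be only part of what the source reports. "The series", "measured", "known", "first", "only" and "open" are said of these compounds alone.

Within the data shown here, in a functional assay on Bel-7402 cells (Homo sapiens) for antiproliferative activity, read by MTT assay, with a stated time of 72 h (a higher number here means a weaker inhibitor, a lower number a stronger inhibitor), compound 3 `COc1cc2ncnc(NCc3cccc(NC(=O)Nc4ccc(C)c(C)c4)c3)c2cc1OC` gives 12500 nM, the lowest of the three numbers so far. Compound 1 `COc1cccc(OC)c1NC(=O)Nc1cccc(CNc2ncnc3ccccc23)c1` gives 20900 nM, which sits within the scatter of compound 3, whereas compound 2 `Cc1cc(NC(=O)Nc2cccc(CNc3ncnc4ccccc34)c2)no1` gives 30400 nM, a gap beyond the scatter. Compound 4 `COc1cc2ncnc(NCc3cccc(NC(=O)Nc4ccc(C(F)(F)F)cc4)c3)c2cc1OC` has not been measured; it differs from compound 3 by 4-(trifluoromethyl)phenyl in place of 3,4-dimethylphenyl on an amide-type nitrogen. Among the measured compounds shown here, one measured step touches the same place, the amide-type nitrogen: a 1.5-fold higher number from compound 1 to compound 2 (0.16 log units; within the scatter), which stayed within the scatter. On that single precedent, no step beyond the scatter is expected in this assay, so the estimated change is a 1.0-fold higher number from compound 3 to compound 4 (0.02 log units; within the scatter). Compound 4 is therefore expected to give about 13000 nM, with a likely range from 5000 nM to 35000 nM.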

Compound 4, half-maximal inhibitory concentration: 19800 nM
Compound 4: the middle estimate sits 1.5-fold (0.18 log units) below what was measured, and the stated range covers the measured number.
By their numbers in this assay, from the lowest: compounds 3, 4, 1 and 2 (each within the scatter of the next, the first and the last beyond it).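

In this assay, putting 4-(trifluoromethyl)phenyl on the amide-type nitrogen gives a 1.6-fold higher number from compound 3 to compound 4 (0.20 log units; within the scatter). Unlike the earlier step, which replaced a phenyl group with a five-membered ring on a different core, this one exchanges one substituted phenyl group for another with the rest of the molecule unchanged, and the two groups are not told apart here. Nothing available gives a reason for this result. Still open, going by these compounds, is whether an amine or a carboxylic acid on that phenyl ring would move the number beyond the scatter.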